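Compound 3 to compound 4: dropping a trifluoromethyl group

This account rests on a few compounds, and the source may have more. Where it says the series, first, only, none or still open, it means among the compounds named here.

Compound 1 `CN1CCN(c2cc(C(=O)Nc3ccc(C4=Nc5cscc5NC(=O)C4)cc3)cc(C(F)(F)F)c2)CC1`: > 30000 nM
Compound 2 `O=C1CC(c2cccc(NC(=O)c3ccccc3-c3ccccc3)c2)=Nc2cscc2N1`: 1030 nM
Compound 3 `O=C1CC(c2ccc(NC(=O)Nc3ccc(Cl)c(C(F)(F)F)c3)cc2)=Nc2cscc2N1`: 4080 nM

In a functional assay on U-937 cells (Homo sapiens) for antiproliferative activity, read by MTT assay, with a stated time of 24 h (on this read-out lower numbers stand for stronger inhibition of growth and higher numbers for weaker inhibition of growth), compound 1 reaches only a limit, > 30000 nM, a case covered by the limit of > 30000 nM in this assay, at which 1 of the 3 values shown sits. Compound 2 gives 1030 nM. Compound 3 gives 4080 nM, the higher of the two numbers, and the gap between compound 2 and compound 3 lies beyond the scatter. Compound 4 `O=C1CC(c2ccc(NC(=O)Nc3ccc(Cl)cc3)cc2)=Nc2cscc2N1` differs from compound 3 by hydrogen in place of trifluoromethyl on an aromatic carbon. Among the compounds with values here, no measured pair follows this change, so the expectation rests on compound 3 alone. The expected step is a 2.0-fold higher number from compound 3 to compound 4 (0.29 log units; within the scatter), a modest rise in the number. The estimate for compound 4 is 8000 nM, with a range from 2500 nM to 25000 nM.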

Compound 4, concentration for 50% growth inhibition: 964 nM
Beside the measured number, compound 4's estimate is 8.3-fold (0.92 log units) above it; the measured number lies below the stated range.
By their numbers in this assay, from the lowest: compounds 4 and 2 (each within the scatter of the next); then compound 3. At a limit, above all of these: compound 1.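

In this assay, within the data shown here, hydrogen in place of trifluoromethyl, ortho to a chloro group, brings a 4.2-fold lower number from compound 3 to compound 4 (0.63 log units; beyond the scatter), the first change at this position with a measured outcome. In this pair, growth inhibition does not depend on trifluoromethyl at this position, and the chloro group alone suffices for the stronger inhibition seen in compound 4. Nothing measured here bears on why the number falls. On these data alone, what a methoxy group or an amine would do at this position stays open. So does whether the same step would hold in a compound without the chloro group.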